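A methyl removed from the fused ring of compound 2

The compounds below may be only part of what the source reports. "The series", "measured", "known", "first", "only" and "open" are said of these compounds alone.

Compound 1 `Cc1nccn1-c1csc(Nc2cccc(Br)c2)n1`: > 100000 nM
Compound 2 `COc1ccc(Nc2nc(-n3c(C)nc4ccccc43)cs2)cc1`: 25 nM
Compound 3 `Cc1cn(-c2csc(Nc3cccc(Br)c3)n2)c(C)n1`: > 100000 nM

Going by the values given here, in a functional assay on RKO cells (Homo sapiens) for cytotoxicity, read by resazurin assay, with a stated time of 72 h (a higher number here means a weaker inhibitor, a lower number a stronger inhibitor), compound 2 gives 25 nM, the only number among the three. Compound 1 gives only a limit, > 100000 nM. Compound 3 also gives only a limit, > 100000 nM. The change from compound 3 to compound 1 is hydrogen in place of methyl on an aromatic carbon, and its step that the two limits leave unreadable from compound 3 to compound 1 cannot be read, because both sit at the limit of > 100000 nM in this assay, at which 2 of the 3 values shown sit. The difference between the core of compound 2 and the core of compound 3 is not broken down here.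

Compound 4 `COc1ccc(Nc2nc(-n3cnc4ccccc43)cs2)cc1` differs from compound 2 by hydrogen in place of methyl on an aromatic carbon. This is the same kind of change as that from compound 3 to compound 1, but the place differs: in compound 2 the carbon lies between two ring nitrogen atoms, within a fused or bridged system of two rings, next to the ring atom that bears a large group, whereas in compound 3 it lies next to the ring nitrogen and two ring bonds from the ring atom that bears a large group. The measured pair supplies no size, so the expectation rests on compound 2 alone, 25 nM, with a step of a 2.4-fold higher number from compound 2 to compound 4 (0.38 log units; beyond the scatter) expected to stay modest. Compound 4 is estimated at 60 nM, between 15 nM and 300 nM.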

Compound 4, half-maximal inhibitory concentration: > 100000 nM
Compound 4: no number, only a limit; the forecaster's own chance of this, stated with the estimate: 5%; middle value at least 1600-fold (3.22 log units) from the limit.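

In this assay compound 4 gives > 100000 nM, which is a limit of the assay and not a number. On the core of compound 2, hydrogen in place of methyl on the aromatic carbon between two ring nitrogen atoms therefore gives an at least 4000-fold higher number from compound 2 to compound 4 (3.60 log units; beyond the scatter), so in this pair the methyl is needed for a measurable value. This does not show that the effect carries over to another core, since the same kind of change, at a different place on the core of compound 3, cannot be read, and any size it might have there stays unknown: the limit of > 100000 nM in this assay, at which 3 of the 4 values shown sit.

Only compound 2 carries a number, so the size of this step rests on a single pair of compounds. From the compounds shown here alone, it remains open whether an ethyl, an amine or a chlorine on that same aromatic carbon would keep a measurable value, or whether the methyl alone does so.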